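A few compounds are considered here, and "the series" means these few. Any claim that something is new, unique, unknown or untested is made for them only; others in the source may bear on it.

In a functional assay on cells (+SA cell, Mus musculus) for cytotoxicity, read by MTT assay, with a stated time of 24 h (a higher number here means a weaker inhibitor, a lower number a stronger inhibitor), compound 1 (`CC(C)=CCC/C(C)=C/CC/C(C)=C/CC[C@]1(C)CCc2c(C)c(OC(=O)c3cc(C(=O)O)ccc3C(=O)O)c(C)c(C)c2O1`) gives 1460 nM, compound 2 (`CC(C)=CCC/C(C)=C/CC/C(C)=C/CC[C@]1(C)CCc2cc(OC(=O)c3cc(C(=O)O)ccc3C(=O)O)c(C)c(C)c2O1`) gives 1440 nM and compound 3 (`CC(C)=CCC/C(C)=C/CC/C(C)=C/CC[C@]1(C)CCc2cc(OC(=O)c3cc(C(=O)O)ccc3C(=O)O)cc(C)c2O1`) gives 1500 nM. Compound 2 therefore stands level with both of the others, since all three values lie within the scatter of one another.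

The next compound, compound 4 (`CC(C)=CCC/C(C)=C/CC/C(C)=C/CC[C@]1(C)CCc2cc(OC(=O)c3ccccc3)c(C)c(C)c2O1`), differs from compound 2 at a new place: phenyl in place of 2,5-dicarboxyphenyl on a carbonyl carbon.

The measured steps offer only indirect help. Each puts hydrogen in place of methyl on an aromatic carbon, giving a 1.0-fold lower number from compound 1 to compound 2 (0.01 log units; within the scatter) and then a 1.0-fold higher number from compound 2 to compound 3 (0.02 log units; within the scatter), both within the scatter. Neither touches the group now being replaced, so their small size cannot be carried over with confidence. This change is also larger than either of those swaps, so a moderate rise in the number is expected, though with much uncertainty.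

The expected change is a 2.1-fold higher number from compound 2 to compound 4 (0.32 log units; beyond the scatter). Compound 4 is estimated at 3000 nM, with an expected range from 1000 nM to 12000 nM.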

Compound 4, half-maximal inhibitory concentration: 6550 nM
The estimate for compound 4 lay 2.2-fold (0.34 log units) below the measured number; the range from low to high includes it.
By their numbers in this assay, from the lowest: compounds 2, 1 and 3 (each within the scatter of the next); then compound 4.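

In this assay, among the compounds shown here, the group on the carbonyl carbon is the first place where a change moves the number beyond the scatter: phenyl in place of 2,5-dicarboxyphenyl gives a 4.5-fold higher number from compound 2 to compound 4 (0.66 log units; beyond the scatter). The earlier swaps of methyl for hydrogen on the aromatic ring left the number level, so among these compounds the result depends more on this group than on those methyl groups, and the form with the two carboxyl substituents gives the lower number. No measurement here explains this shift.

Since both carboxyl substituents go at once, the compounds shown cannot tell whether one alone would keep the lower number. A phenyl carrying a single carboxylic acid, or an amine in their place, would help to separate these possibilities.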